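Ethoxy in Place of Pentylsulfanyl: the Expected Activation Value

A few compounds are considered here, and "the series" means these few. Any claim that something is new, unique, unknown or untested is made for them only; others in the source may bear on it.

Of the compounds shown here, three on a shared core have been measured in a functional assay (spleen, spleen) for activation, with Mus musculus as the target; on this read-out higher numbers stand for an effect only at larger amounts of compound and lower numbers for an effect already at smaller amounts. Compound 1 `COc1ccc(Cn2c(O)nc3c(N)ncnc32)cc1` gives 10 uM, and compound 2 `Nc1ncnc2c1nc(O)n2Cc1ccc(Cl)cc1` gives 10 uM, so that the step of no change at the digits printed from compound 1 to compound 2 (within the scatter), chloro in place of methoxy on an aromatic carbon, stays within the scatter. Compound 3 `CCCCCSc1nc(N)c2nc(O)n(Cc3ccccc3)c2n1` gives 10 uM in this assay and stands level with compounds 1 and 2 at the digits shown, nearest to compound 1 and furthest from compound 2, with no change beyond the scatter either way.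

Compound 4 `CCOc1nc(N)c2nc(O)n(Cc3ccccc3)c2n1` differs from compound 3 by ethoxy in place of pentylsulfanyl on an aromatic carbon. For the measured compounds named here, no measured step touches this position of the core; the only step measured, no change at the digits printed from compound 1 to compound 2 (within the scatter), altered a group on a different ring and moved nothing beyond the scatter. With all three measured values level, the expected step is no change at the digits printed from compound 3 to compound 4 (within the scatter), within the scatter. Compound 4 is therefore estimated at 10 uM, in a range from 3 uM to 30 uM.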

Compound 4, minimum effective concentration: 0.1 uM
Beside the measured number, compound 4's estimate is 100-fold (2.00 log units) above it, and the stated range ends above it.
By their numbers in this assay, from the lowest: compound 4; then compounds 1, 2 and 3 (each within the scatter of the next).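

For the compounds shown here, the step of a 100-fold lower number from compound 3 to compound 4 (2.00 log units; beyond the scatter) shows that in this assay this position, on an aromatic carbon between two ring nitrogen atoms, responds strongly to the group it carries, whereas the one earlier step, on a different ring, stayed within the scatter. The change replaces pentylsulfanyl, with 6 heavy atoms, by ethoxy, with 3, while the counts of hydrogen-bond donors and acceptors and the net charge stay the same, so the large step comes with a shorter group and oxygen in place of sulfur. No measurement is available that explains the step.

The compounds shown leave open whether the oxygen or the shorter chain carries the effect, which a pentyloxy or an ethylsulfanyl group at this place could separate. They also leave open how a methoxy group or an amine would read out here.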